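This account rests on a few compounds, and the source may have more. Where it says the series, first, only, none or still open, it means among the compounds named here.

Values so far in a physicochemical assay for solubility, in phosphate buffer, at pH 7.4; a higher number here means a more soluble compound, a lower number a less soluble compound

- compound 1 `OCC1CCN(c2nccnc2Oc2ccc(Nc3nc4ccccc4s3)cc2)CC1` gives 6000 nM
- compound 2 `OCC1CCN(c2cccnc2OC2CN(c3ccc4ccccc4n3)C2)CC1` gives 189000 nM
- compound 3 `OC1CCN(c2nccnc2OC2CN(c3ccc4ccccc4n3)C2)CC1` gives 99000 nM

Compound 3 (99000 nM) lies within the scatter of compound 2 (189000 nM). Compound 1 (6000 nM) lies beyond the scatter on the low side of compound 3, so compound 3 sits in the upper part of this small range.

Next is compound 4 `c1ccc2nc(N3CC(Oc4nccnc4N4CCCCC4)C3)ccc2c1`, not yet measured. It differs from compound 3 in one place (hydrogen in place of hydroxy on a saturated ring carbon), the change from 4-hydroxypiperidin-1-yl to piperidin-1-yl, with hydrogen in place of hydroxy on a saturated ring carbon.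

For the measured compounds named here, no measured pair isolates this change, and the three values offer no direct calibration of it. The expectation therefore rests on the structural change alone and carries a wide range. A lower number in this assay is expected, with an estimated 3.3-fold lower number from compound 3 to compound 4 (0.52 log units; beyond the scatter) that would lie modestly beyond the scatter. Compound 4 is expected at 30000 nM (estimated range 8000 nM to 90000 nM).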

Compound 4, solubility: < 1000 nM
Compound 4 ended at the assay's limit; the forecaster's own chance of this, stated with the estimate: 3%; at least 30-fold (1.47 log units) between middle value and limit.
By their numbers in this assay, from the lowest: compound 1; then compounds 3 and 2 (each within the scatter of the next). At a limit, below all of these: compound 4.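

In this assay, for the compounds shown here, the change from 4-hydroxypiperidin-1-yl to piperidin-1-yl gives the first one-place comparison: an at least 99-fold lower number from compound 3 to compound 4 (1.99 log units; beyond the scatter). Compound 4 sits at a limit of the assay, so this step has a floor and no exact size: the limit of < 1000 nM in this assay, at which 1 of the 4 values shown sits. The step shows that, in this pair, the read-out depends strongly on what stands on the saturated ring carbon three ring bonds from the ring nitrogen, a position that compounds 1 to 3 gave no isolated reading of.

On these data alone, whether an amine, a methoxy group or a carboxylic acid on this ring carbon would stay close to compound 3 at 99000 nM remains open. Also open, as far as these compounds go, is whether replacing hydroxy with hydrogen gives a step of similar size on another core.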